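Expected loss from a smaller amine on a shared core

The source may hold more compounds than are shown below. What is called first, only, known or untested is meant among the compounds shown, and "the series" means these compounds.

Measured so far:
compound 2, `CCCCN(CC)c1nc(C)nc2c1ncn2-c1ccc(C(C)C)cc1Br`: 4.3 nM
compound 1, `CCN(c1nc(C)nc2c1nnn2-c1ccc(C(C)C)cc1Br)C(COC)COC`: 123 nM

In an in vitro assay on 293-EBNA cells for binding affinity to corticotropin-releasing factor receptor 1 (Homo sapiens) (a higher number here means a weaker inhibitor, a lower number a stronger inhibitor), compound 2 gives 4.3 nM, the lower of the two numbers, and in this assay compound 1 gives 123 nM; the two compounds differ in more than one place, so the gap between them, which lies beyond the scatter, is not tied to a single change. Compound 3, `COCCNc1nc(C)nc2c1ncn2-c1ccc(C(C)C)cc1Br`, has not yet been measured. It differs from compound 2 by (2-methoxyethyl)amino in place of butyl(ethyl)amino on an aromatic carbon. For the measured compounds named here, with no measured pair isolating such a change, the direction is uncertain, but a smaller amine with a donor in place of the dialkylamino group is expected to give a higher number, by a step beyond the scatter, a 19-fold higher number from compound 2 to compound 3 (1.27 log units; beyond the scatter). Compound 3 is therefore estimated at 80 nM in this assay, within a range from 15 nM to 400 nM.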

Compound 3, inhibition constant: 210 nM
Beside the measured number, compound 3's estimate is 2.6-fold (0.42 log units) below it; low and high end bracket the measured number.
By their numbers in this assay, from the lowest: compound 2; then compounds 1 and 3 (each within the scatter of the next).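

In this assay, for the compounds shown here, this is the first comparison that isolates the group on this aromatic carbon of the shared core, and it gives a 49-fold higher number from compound 2 to compound 3 (1.69 log units; beyond the scatter), a large step. Replacing butyl(ethyl)amino with (2-methoxyethyl)amino therefore raises the number well beyond the scatter. The change alters several things at once: the entering group has fewer heavy atoms, adds an oxygen and brings one hydrogen-bond donor where the leaving group has none, and nothing available here bears on the cause of the step.

The compounds shown leave open which of these differences accounts for the step. Also open, as far as these compounds go, is how butylamino, which keeps a carbon chain and has an amine hydrogen, and ethyl(2-methoxyethyl)amino, which keeps the oxygen without that hydrogen, would read in this assay.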